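The compounds below may be only part of what the source reports. "The series", "measured", "known", "first", "only" and "open" are said of these compounds alone.

In an in vitro ADME assay on microsomes from liver (Homo sapiens) for metabolic stability, tested at 1 uM (on this read-out lower numbers stand for a shorter-lived compound and higher numbers for a longer-lived compound), compound 1 `COc1cc(-c2cc(-c3ccc(S(C)(=O)=O)cc3)cnc2N)ccc1O` gives 1.72 h. Compound 2 `COc1ccc(-c2cc(-c3ccc(S(C)(=O)=O)cc3)cnc2N)cn1` is reported only as a limit, > 1.65 h. On these data alone, compound 3 `Cc1ccc(-c2cc(-c3ccc(S(C)(=O)=O)cc3)cnc2N)cn1` is also reported only as a limit, > 5.83 h, so its real half-life remains unknown. Compound 4 `CS(=O)(=O)c1ccc(-c2cnc(N)c(-c3ccc(CO)nc3)c2)cc1` differs from compound 3 by hydroxy in place of hydrogen on a saturated chain carbon bound to an aromatic carbon, turning methyl into hydroxymethyl. Within the data shown here, the one measured step touching this group, a step that the two limits leave unreadable from compound 2 to compound 3, cannot be read, so it gives no size to carry over. Among the measured compounds shown here, the only hydroxy-bearing compound with a real number is compound 1, at 1.72 h, and this points weakly towards a shorter half-life. A moderate shortening is therefore expected in this assay, with the estimated step being an at least 1.4-fold lower number from compound 3 to compound 4 (0.16 log units; that floor lies within the scatter). For compound 4 the estimate is 4 h, with an expected range of 1.5 h to 10 h.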

Compound 4, half-life: > 4.16 h
Compound 4 gave a limit, no number; the forecaster's own chance of this, stated with the estimate: 40%; middle value at least 1.0-fold (0.01 log units) from the limit.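

Compound 4 is reported only as a limit, like compound 2 and compound 3, so neither step to compound 4 can be read. The compounds shown leave open whether hydroxymethyl in place of methyl changes the half-life in this assay.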